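The source may report more compounds than this note shows. Statements on the series, on what has been measured and on what is new or still open speak of the compounds shown alone.

Measured in a functional assay on MCF7 cells (Homo sapiens) for cytotoxicity, read by MTT assay, with a stated time of 72 h; a lower number here means a stronger inhibitor of growth, a higher number a weaker inhibitor of growth:

- compound 1 `COc1ccc(OC(=O)Nc2ccc([Se]C#N)cc2)cc1`: 22400 nM
- compound 2 `CC(C)COC(=O)Nc1ccc([Se][Se]c2ccc(NC(=O)OCC(C)C)cc2)cc1`: 19000 nM
- compound 3 `CCCCOC(=O)Nc1ccc([Se][Se]c2ccc(NC(=O)OCCCC)cc2)cc1`: 17300 nM

Compound 1 stands highest of the three numbers, but its nearest neighbour, compound 2, lies within the usual scatter of it, and so does compound 3, the furthest of the three. The three measured values therefore do not separate the compounds from one another; none can be called weaker or stronger than the others on this evidence. Among the measured compounds shown here, no pair among the measured compounds differs in a single place, so no isolated structural step is available from the data.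

Compound 4 `N#C[Se]c1ccc(NC(=O)Oc2ccc(Cl)cc2)cc1` is the next member. Relative to compound 1 the change is chloro in place of methoxy on an aromatic carbon. For the measured compounds named here, no measured pair shows what this exchange does in this assay, and the three measured values all sit close together. The step from compound 1 to compound 4 is therefore expected to be a 1.1-fold lower number from compound 1 to compound 4 (0.05 log units; within the scatter), that is, nothing beyond the scatter in either direction. For compound 4 the estimated value in this assay is 20000 nM, with a range from 7000 nM to 60000 nM. As far as these compounds go, the range is wide: the change itself is untested.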

Compound 4, concentration for 50% growth inhibition: 6000 nM
Compound 4: the middle estimate sits 3.3-fold (0.52 log units) above what was measured, outside the stated range (below it).
By their numbers in this assay, from the lowest: compound 4; then compounds 3, 2 and 1 (each within the scatter of the next).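

In this assay, chloro in place of methoxy on an aromatic carbon, para to a large group, gives a 3.7-fold lower number from compound 1 to compound 4 (0.57 log units; beyond the scatter). This is the only single-place step in the compounds shown, and it shows that the number responds to what sits at this position while the rest of compound 1 stays unchanged. By count, the exchange removes one hydrogen-bond acceptor and replaces a two-atom group with a single atom, but nothing measured links the step to these counts or to any property of either group, so the data give no explanation for it.

As far as these compounds go, with a single pair, it remains open whether the step reflects the arrival of chloro, the departure of methoxy or both, and hydrogen, fluoro, bromo or trifluoromethyl at the same carbon would help to separate these readings. From the compounds shown here alone, it is also open whether the same exchange carries over to the diselenide compounds, and how a selenocyanate and a diselenide compare when they share the same carbamate group.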